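A few compounds are considered here, and "the series" means these few. Any claim that something is new, unique, unknown or untested is made for them only; others in the source may bear on it.

Measured compounds:
- compound 1, `C/N=C(\S)n1ncnc1N` — 93%
- compound 2, `CCC/N=C(\S)n1ncnc1N` — 93%
- compound 3, `CCCCCC/N=C(\S)n1ncnc1N` — -1%

In a functional assay on the whole organism for inhibition, with Rattus norvegicus as the target, at a dose of 30 mg/kg (on this read-out lower numbers stand for less inhibition and higher numbers for more inhibition at the one dose given (going by the name of the read-out)), compound 1 gives 93% and compound 2 gives 93%; the step of no change at the digits printed from compound 1 to compound 2 (within the scatter) shows that ethyl in place of hydrogen on a saturated chain carbon bound to a double-bonded nitrogen leaves the read-out where it was. Compound 3 gives -1% and stands lowest of the three numbers, as the steps of a number 94 percentage points lower from compound 1 to compound 3 (beyond the scatter) and a number 94 percentage points lower from compound 2 to compound 3 (beyond the scatter) make plain: lengthening the chain to this extent takes the inhibition away entirely.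

Compound 4, `Nc1ncnn1/C(S)=N/CCCCCO`, keeps the chain of compound 3 and differs from it by hydroxy in place of methyl on a saturated chain carbon, five bonds along the chain from a double-bonded nitrogen. Within the data shown here, no measured step exchanges a methyl for a hydroxy anywhere, so none bears directly on this change; the only steps that touch the chain at all, a number 94 percentage points lower from compound 1 to compound 3 (beyond the scatter) and a number 94 percentage points lower from compound 2 to compound 3 (beyond the scatter), concern its length, which compound 4 does not alter. The account therefore expects compound 4 to stay close to compound 3, with a step of a number 16 percentage points higher from compound 3 to compound 4 (beyond the scatter) that may not exceed the scatter, though the range is left wide. The expected value for compound 4 is 15%, between -10% and 55%.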

Compound 4, a percentage reported as inhibition, in the whole organism at one dose (the size of the read-out at that dose, not a potency): -17%
For compound 4 the middle estimate is 32 percentage points above the measured one; the measured number lies below the stated range.
By their numbers in this assay, from the lowest: compound 4; then compound 3; then compounds 1 and 2 (each within the scatter of the next).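

In this assay, the change from methyl to hydroxy on a saturated chain carbon, five bonds along the chain from a double-bonded nitrogen, is the first shown that alters the end of the chain and not its length, and a number 16 percentage points lower from compound 3 to compound 4 (beyond the scatter) shows that the read-out still moves with this change even after the long chain has taken the inhibition away. The hydroxy does not bring back what the shorter chains give, since the long chain that carries it stays far from them, with a number 110 percentage points lower from compound 2 to compound 4 (beyond the scatter) and a number 110 percentage points lower from compound 1 to compound 4 (beyond the scatter). Nothing at hand explains why the number moves in this direction at this position.

Going by these compounds, it remains open whether an amine or a carboxylic acid at the same chain end would move the read-out in the same direction as the hydroxy, or whether a methoxy would behave as the hydroxy does. Also open, on these data alone, is what a hydroxy would do on the shorter chain of compound 2, where the inhibition is still intact.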